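Methyl in Place of Fluoro on the Shared Core

The compounds below may be only part of what the source reports. "The series", "measured", "known", "first", "only" and "open" are said of these compounds alone.

Compound 1 `Nc1nc(-c2c(F)cccc2F)cs1` reaches only a limit in a functional assay for agonist activity at thrombopoietin receptor (Homo sapiens) (on this read-out higher numbers stand for an effect only at larger amounts of compound and lower numbers for an effect already at smaller amounts), namely > 10000 nM. Compound 2 `Nc1nc(-c2cccc(C(F)(F)F)c2F)cs1` gives 57 nM in this assay. Compound 3 `Nc1nc(-c2cccc(C(F)(F)F)c2F)c(F)s1` gives 700 nM, the highest of the two numbers shown, and a 12-fold higher number from compound 2 to compound 3 (1.09 log units; beyond the scatter). Compound 4 `Cc1sc(N)nc1-c1cccc(C(F)(F)F)c1F` differs from compound 3 by methyl in place of fluoro on an aromatic carbon. Among the compounds with values here, the only measured step that touches the same position is the one from hydrogen to fluoro, which was large and upward; a methyl there has not been tested, so the size is uncertain, but a further upward step or none beyond the scatter seems the likelier outcome. Compound 4 is therefore estimated at 1200 nM, between 250 nM and 6000 nM. This expectation corresponds to a 1.7-fold higher number from compound 3 to compound 4 (0.23 log units; within the scatter).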

Compound 4, half-maximal effective concentration: 540 nM
For compound 4 the middle estimate is 2.2-fold (0.35 log units) above the measured one; measured number inside the range.
By their numbers in this assay, from the lowest: compound 2; then compounds 4 and 3 (each within the scatter of the next). At a limit, above all of these: compound 1.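

Methyl on this aromatic carbon next to the ring sulfur behaves like fluoro, with a 1.3-fold lower number from compound 3 to compound 4 (0.11 log units; within the scatter). Set against hydrogen, it gives a 9.5-fold higher number from compound 2 to compound 4 (0.98 log units; beyond the scatter), so the rise seen earlier with fluoro is not confined to that one group: of the three groups on this carbon, hydrogen in compound 2 has the lowest number, and fluoro and methyl stand together. Nothing among the data shown gives a reason for these steps. Going by these compounds, what remains open is whether an ethyl chain, a methoxy group or an amine on this carbon would stay with compound 3 and compound 4 or come back towards compound 2.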